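The source may report more compounds than this note shows. Statements on the series, on what has been measured and on what is new or still open speak of the compounds shown alone.

Compound 1 `Cc1ccc(N2CC(c3nc(-c4cccc(Cl)c4)no3)CC2=O)cc1C` gives 310 nM in an in vitro functional assay on HEK293-A cells for positive allosteric modulation of metabotropic glutamate receptor 5 (Homo sapiens), read by FLIPR and calcium flux; a lower number here means that less compound is needed, a higher number that more compound is needed for the effect. Compound 2 `COc1cccc(N2CC(c3nc(-c4cccc(Cl)c4)no3)CC2=O)c1` reaches only a limit in this assay, > 10000 nM. Going by the values given here, the single measured step, an at least 32-fold higher number from compound 1 to compound 2 (1.50 log units; beyond the scatter), is the one that bears on the present question, with the reservation that compound 2 sits at the limit of > 10000 nM in this assay, at which 1 of the 2 values shown sits, and its true distance from compound 1 is therefore known only as a bound. Compound 3 `Cc1cccc(N2CC(c3nc(-c4cccc(Cl)c4)no3)CC2=O)c1` differs from compound 2 by methyl in place of methoxy on an aromatic carbon, on an aromatic carbon of a six-membered aromatic ring of carbon only, meta to a large group. Compound 3 thus carries one of the two methyls of compound 1 and no methoxy. Because an at least 32-fold higher number from compound 1 to compound 2 (1.50 log units; beyond the scatter) was large, a clearly lower number than the limit of compound 2 is expected, though without the second methyl of compound 1 the full return is uncertain. Compound 3 is expected to give about 1500 nM in this assay, between 400 nM and 8000 nM. The expected step is an at least 6.6-fold lower number from compound 2 to compound 3 (0.82 log units; beyond the scatter).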

Compound 3, half-maximal effective concentration: > 10000 nM
Compound 3 ended at the assay's limit; the forecaster's own chance of this, stated with the estimate: 25%; at least 6.6-fold (0.82 log units) between middle value and limit.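

The 3-methylphenyl group of compound 3 does not restore a readable value in this assay. Compound 3 gives > 10000 nM, which is a limit of the assay. Hydrogen in place of methyl on an aromatic carbon gives an at least 32-fold higher number from compound 1 to compound 3 (1.50 log units; beyond the scatter), so this one change to compound 1 is enough to reach the limit, with no methoxy present, and the steep loss seen with compound 2 cannot be tied to the methoxy alone. The step from methoxy to methyl cannot be read, and no order can be given for these two groups: the limit of > 10000 nM in this assay, at which 2 of the 3 values shown sit.

On these data alone, how far the true values of compound 2 and compound 3 lie beyond the limit remains open. Also open, as far as these compounds go, is whether a chlorine atom, a trifluoromethyl group or an amine in place of the methyl of compound 3 would give a readable value.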